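Changing the Sulfonyl Group of Compound 3

The source may report more compounds than this note shows. Statements on the series, on what has been measured and on what is new or still open speak of the compounds shown alone.

In a functional assay on A2780 cells (Homo sapiens) for cytotoxicity, read by sulforhodamine B assay, with a stated time of 72 h (a higher number here means a weaker inhibitor, a lower number a stronger inhibitor), compound 3 (`CC(C)n1cc(S(=O)(=O)c2ccc(CNC(=O)N3Cc4ccncc4C3)cc2)cn1`) gives 11 nM while compound 1 (`O=C(NCc1ccc(S(=O)(=O)c2ccccc2)cc1)c1cc2cnccc2[nH]1`) gives 18 nM as its value, a pair within the usual scatter of each other. Compound 2 (`O=C(NCc1ccc(S(=O)(=O)c2ccccc2)cc1)N1Cc2cccnc2C1`) returns only a limit of the assay (> 2000 nM) rather than a number. Compound 3 thus sits together with compound 1 at the low, strongly inhibiting end of these results.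

Compound 4 (`CN1CCC(S(=O)(=O)c2ccc(CNC(=O)N3Cc4ccncc4C3)cc2)CC1`) differs from compound 3 in one place, on a sulfonyl sulfur, where 1-methylpiperidin-4-yl stands in place of 1-isopropyl-1H-pyrazol-4-yl (1-methylpiperidin-4-yl in place of 1-isopropyl-1H-pyrazol-4-yl on a sulfonyl sulfur).

Within the data shown here, the only measured step (an at least 110-fold higher number from compound 1 to compound 2 (2.04 log units; beyond the scatter)) is large and shows that one swap can move the number a long way. However, it concerns a group on a carbonyl carbon, not on the sulfonyl sulfur, so it fixes no size for this change. Among the measured compounds shown here, with a whole group replaced and no measured step at this place, the expected change is a moderate one toward weaker inhibition (a 3.6-fold higher number from compound 3 to compound 4 (0.56 log units; beyond the scatter)) in this assay and the margin is wide. For compound 4 the expected value is 40 nM within an estimated range of 8 nM to 200 nM (a result still to be measured).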

Compound 4, half-maximal inhibitory concentration: 99 nM
Beside the measured number, compound 4's estimate is 2.5-fold (0.39 log units) below it; the measured number falls inside the stated range.
By their numbers in this assay, from the lowest: compounds 3 and 1 (each within the scatter of the next); then compound 4. At a limit, above all of these: compound 2.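

The sulfonyl sulfur of compound 3 now has a measured change of its own: in this assay, the swap gives a 9.0-fold higher number from compound 3 to compound 4 (0.95 log units; beyond the scatter). The exchange of 1-isopropyl-1H-pyrazol-4-yl, a five-membered aromatic ring, for 1-methylpiperidin-4-yl, a six-membered non-aromatic ring, therefore weakens inhibition at this place, yet compound 4 still returns a real number and not a limit of the assay. Nothing measured here accounts for the size of this step.

Several features change together in this single swap, so the ring size, the aromatic character of the ring and the group on its nitrogen cannot be told apart from these compounds. A 1-methyl-1H-pyrazol-4-yl group, which would keep the aromatic ring of compound 3 and carry a methyl group as in compound 4, and a piperidin-4-yl group with no group on its nitrogen are among the groups whose effect on the sulfonyl sulfur remains an open question.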